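Acetoxy to hydroxy on compound 2

The compounds below may be only part of what the source reports. "The series", "measured", "known", "first", "only" and "open" are said of these compounds alone.

In an ADME assay on cells (Peritoneal macrophage cell, Mus musculus) for cytotoxicity, read by MTT assay, with a stated time of 72 h (a higher number here means that more compound is tolerated, a lower number that less compound is tolerated), compound 1 (`CS(=O)(=O)OCCCCCCCCCCCCn1cc(CCCOS(C)(=O)=O)nn1`) gives 156000 nM, while compound 2 (`CC(=O)OCCCc1cn(CCCCCCCCCCCCOS(C)(=O)=O)nn1`) gives 26600 nM, the lower of the two numbers. Compound 2 is thus the less tolerated of the pair. Among the measured compounds shown here, the only measured step, a 5.9-fold lower number from compound 1 to compound 2 (0.77 log units; beyond the scatter), is modest but beyond the scatter, and it put acetyl in place of methylsulfonyl on an oxygen on a saturated carbon.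

Compound 3 (`CS(=O)(=O)OCCCCCCCCCCCCn1cc(CCCO)nn1`) departs from compound 2 at that kind of site: hydrogen in place of acetyl on an oxygen on a saturated carbon. In words, hydrogen takes the place of acetyl on an oxygen on a saturated carbon, turning acetoxy to hydroxy. For the measured compounds named here, no measured compound carries the free hydroxy, so the single step is a thin guide. Since the arrival of acetyl went with the fall of a 5.9-fold lower number from compound 1 to compound 2 (0.77 log units; beyond the scatter), its removal is expected to recover part of that fall, not all of it. The expected change is a modest rise, a 2.3-fold higher number from compound 2 to compound 3 (0.35 log units; beyond the scatter). For compound 3 the estimated value is 60000 nM, with an expected range of 20000 nM to 180000 nM.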

Compound 3, half-maximal cytotoxic concentration: 163000 nM
The estimate for compound 3 lay 2.7-fold (0.43 log units) below the measured number; the range from low to high includes it.
By their numbers in this assay, from the lowest: compound 2; then compounds 1 and 3 (each within the scatter of the next).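

Taking the acetyl off compound 2 gives a 6.1-fold higher number from compound 2 to compound 3 (0.79 log units; beyond the scatter), so in this assay the earlier fall is undone in full at this oxygen on a saturated carbon, not just in part. The comparison of the free hydroxy with methylsulfonyl on the same oxygen gives a 1.0-fold higher number from compound 1 to compound 3 (0.02 log units; within the scatter), which is within the scatter, so compound 1 and compound 3 cannot be told apart, and among the three groups seen here only acetyl goes with a lower number. No measurement at hand accounts for acetyl standing apart from hydrogen and methylsulfonyl.

The three compounds leave open whether the lower number belongs to acetyl alone or would also come with a longer acyl group such as propanoyl or benzoyl, or with a methyl ether on the same oxygen. They also leave open what an amine or a carboxylic acid would do at the end of this side chain, and whether the methylsulfonyl group shared by all three compounds on the other chain matters to the numbers at all.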